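Trading pyrrolidin-1-yl for hydroxymethyl on the side chain

This account rests on a few compounds, and the source may have more. Where it says the series, first, only, none or still open, it means among the compounds named here.

Of the compounds shown here, three sharing one amide-linked core have been measured so far in an assay for inhibition of RAC-alpha serine/threonine-protein kinase (Homo sapiens), read by HTRF, with a stated time of 1 h; on this read-out lower numbers stand for stronger inhibition and higher numbers for weaker inhibition. Compound 1 `Cn1ncc(Cl)c1-c1cc(C(=O)N[C@@H]2CNCC[C@H]2c2ccc(C(F)(F)F)cc2)oc1Cl` gives 9.3 nM. Compound 2 `Cn1ncc(Cl)c1-c1cc(C(=O)N[C@@H]2CN[C@H](CCN3CCCC3)C[C@H]2c2ccc(Cl)c(Cl)c2)oc1Cl` gives 6.41 nM. Compound 3 `Cn1ncc(Cl)c1-c1cc(C(=O)N[C@@H]2CN[C@H](CC(O)CO)C[C@H]2c2ccc(F)c(F)c2)oc1Cl` gives 3.31 nM. Among these three numbers compound 2 stands second highest; its nearest neighbour is compound 1, and its furthest is compound 3, yet both of those gaps lie within the usual scatter of this assay, so the three compounds cannot be ordered against one another on the evidence at hand.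

The next compound to be tested is compound 4 `Cn1ncc(Cl)c1-c1cc(C(=O)N[C@@H]2CN[C@H](CCCO)C[C@H]2c2ccc(Cl)c(Cl)c2)oc1Cl`. It differs from compound 2 in one place: hydroxymethyl in place of pyrrolidin-1-yl on a saturated chain carbon, two bonds along the chain from a saturated ring carbon. Everything else, including the dichlorophenyl group and the shared core, is kept.

Among the compounds with values here, no measured pair in this set isolates this particular change, so the expectation rests only on the spread of the three known values, all of which sit within scatter of one another despite quite different side chains on the same chain carbon. On that basis the step is expected to be small, with a 1.2-fold lower number from compound 2 to compound 4 (0.07 log units; within the scatter) not going beyond the scatter in either direction. Compound 4 is therefore estimated at 5.5 nM, within a range from 2 nM to 15 nM.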

Compound 4, half-maximal inhibitory concentration: 2.56 nM
Compound 4: the middle estimate sits 2.1-fold (0.33 log units) above what was measured; low and high end bracket the measured number.
By their numbers in this assay, from the lowest: compounds 4, 3, 2 and 1 (each within the scatter of the next, the first and the last beyond it).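

Within the data shown here, the exchange of pyrrolidin-1-yl for hydroxymethyl on a saturated chain carbon, two bonds along the chain from a saturated ring carbon, gives in this assay a 2.5-fold lower number from compound 2 to compound 4 (0.40 log units; beyond the scatter) and is the first change in this set that can be read on its own. Among these compounds, the step is modest, but it lies beyond the scatter, so the group at the end of this side chain does bear on the number, which the earlier compounds, differing in more than one place, could not show. With the dichlorophenyl group and the shared core kept, the ring of pyrrolidin-1-yl is not needed at this position for a low number, though no measurement at hand explains why the number falls.

On these data alone, a single pair cannot separate the loss of the ring from the arrival of the hydroxyl group, so it remains open how a primary amine, a carboxylic acid, a methyl ether or a longer chain ending in a hydroxyl group would fare in the same place. As far as these compounds go, it also remains open whether the step would hold with the difluorophenyl group of compound 3 or the trifluoromethyl-bearing phenyl group of compound 1 in place of the dichlorophenyl group.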